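The source may report more compounds than this note shows. Statements on the series, on what has been measured and on what is new or still open speak of the compounds shown alone.

In a functional assay on MCF7 cells (Homo sapiens) for inhibition, read by resazurin assay, with a stated time of 24 h (a higher number here means a weaker inhibitor, a lower number a stronger inhibitor), compound 1, `O=C1Nc2c(C(F)(F)F)cccc2C1(c1ccc(O)cc1)c1ccc(OC(F)(F)F)cc1`, gives 20 nM, and compound 2, `O=C1Nc2c(C(F)(F)F)cccc2C1(c1ccc(OC(F)(F)F)cc1)c1c(F)cc(O)cc1F`, gives 549 nM. Compound 2 therefore holds the higher of the two numbers and is the weaker inhibitor. The next compound, compound 3, `Cc1cc(C2(c3ccc(OC(F)(F)F)cc3)C(=O)Nc3c(C(F)(F)F)cccc32)cc(C)c1O`, keeps the shared core and changes only the aryl group on the saturated ring carbon: 4-hydroxy-3,5-dimethylphenyl in place of 2,6-difluoro-4-hydroxyphenyl, (4-hydroxy-3,5-dimethylphenyl in place of 2,6-difluoro-4-hydroxyphenyl on a saturated ring carbon).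

Going by the values given here, only one measured step bears on this change: a 27-fold higher number from compound 1 to compound 2 (1.44 log units; beyond the scatter), which came with 2,6-difluoro-4-hydroxyphenyl in place of 4-hydroxyphenyl. Compound 3 carries no fluorine on this ring, so part of that large loss might be recovered. However, no measured compound shows what the two methyl groups do, and a full return to the value of compound 1 cannot be assumed. A moderate move towards a lower number in this assay is therefore expected, though with wide uncertainty. The expected change is a 2.7-fold lower number from compound 2 to compound 3 (0.44 log units; beyond the scatter). For compound 3 the estimated value is 200 nM, with an expected range from 40 nM to 1000 nM.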

Compound 3, half-maximal inhibitory concentration: > 1000 nM
Compound 3 ended at the assay's limit (the forecaster's own chance of this, stated with the estimate: 8%); at least 5.0-fold (0.69 log units) between middle value and limit.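

In this assay compound 3 gives > 1000 nM, which is a limit of the assay and not a number: the limit of > 1000 nM in this assay, at which 1 of the 3 values shown sits. The change from 4-hydroxyphenyl to 4-hydroxy-3,5-dimethylphenyl on the saturated ring carbon brings an at least 50-fold higher number from compound 1 to compound 3 (1.69 log units; beyond the scatter), so the large loss seen earlier, a 27-fold higher number from compound 1 to compound 2 (1.44 log units; beyond the scatter), is not confined to the fluorine-bearing ring and also appears with methyl groups. The direct exchange of 2,6-difluoro-4-hydroxyphenyl for 4-hydroxy-3,5-dimethylphenyl gives an at least 1.8-fold higher number from compound 2 to compound 3 (0.26 log units; that floor lies within the scatter), so taking the fluorines away at this position does not by itself restore a value near that of compound 1.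

The limit leaves open how far compound 3 truly lies from compound 2, and the fluorine and methyl patterns cannot be ranked against each other from these values. As far as these compounds go, it also remains open whether a single fluorine, a single methyl or a methoxy group on the 4-hydroxyphenyl ring would stay close to compound 1, and whether an amine or a carboxylic acid could take the place of the hydroxyl group.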